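Placing 4-methylbenzyl on the aromatic nitrogen of compound 3

A few compounds are considered here, and "the series" means these few. Any claim that something is new, unique, unknown or untested is made for them only; others in the source may bear on it.

In a functional assay on A549 cells (Homo sapiens) for cytotoxicity, read by MTT assay, with a stated time of 72 h (a higher number here means a weaker inhibitor, a lower number a stronger inhibitor), compound 3 `CN(C)Cc1ccc2nc(NC(=O)N/N=C/c3c[nH]c4ccccc34)sc2c1` gives 3300 nM. That number lies within the scatter of compound 1 `CN(C)Cc1ccc2nc(NC(=O)N/N=C/c3cn(Cc4ccc(C(C)(C)C)cc4)c4ccccc34)sc2c1` at 1850 nM, while compound 2 `CCN(CC)Cc1ccc2nc(NC(=O)N/N=C/c3cn(Cc4ccc(C)cc4)c4ccccc34)sc2c1` at 1510 nM stands lower, beyond the scatter of compound 3.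

Compound 4 `Cc1ccc(Cn2cc(/C=N/NC(=O)Nc3nc4ccc(CN(C)C)cc4s3)c3ccccc32)cc1` differs from compound 3 in one place: 4-methylbenzyl in place of hydrogen on an aromatic nitrogen. The closest measured precedent is the same kind of exchange run the other way, with hydrogen in place of 4-(tert-butyl)benzyl on an aromatic nitrogen. That step is a 1.8-fold higher number from compound 1 to compound 3 (0.25 log units; within the scatter), which stays within the scatter. Compound 2 also carries 4-methylbenzyl, but it differs from compound 4 elsewhere in the structure, so it offers only loose support.

A lower number of similar size is therefore expected, and it would not clearly exceed the scatter. The expected step is a 1.8-fold lower number from compound 3 to compound 4 (0.26 log units; within the scatter). For compound 4 the estimate is 1800 nM, with an expected range of 950 nM to 3300 nM.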

Compound 4, half-maximal inhibitory concentration: 1600 nM
Estimate against measurement, compound 4: 1.1-fold (0.05 log units) above, within the range that was stated.
By their numbers in this assay, from the lowest: compounds 2, 4, 1 and 3 (each within the scatter of the next, the first and the last beyond it).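

In this assay the exchange of hydrogen for 4-methylbenzyl on the aromatic nitrogen gives a modest step that passes the scatter (a 2.1-fold lower number from compound 3 to compound 4 (0.31 log units; beyond the scatter)), whereas the exchange involving 4-(tert-butyl)benzyl at this nitrogen stayed within it. Compounds 1 and 4 cannot be told apart, so methyl in place of tert-butyl on the aromatic carbon of the benzyl group makes no difference that can be read (a 1.2-fold lower number from compound 1 to compound 4 (0.06 log units; within the scatter)). Nor can dimethylamino in place of diethylamino be read as a difference between compound 2 and compound 4 (a 1.1-fold higher number from compound 2 to compound 4 (0.03 log units; within the scatter)).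

The data shown offer no explanation for any of these steps. As far as these compounds go, it stays open how a benzyl group bearing a carboxylic acid or an amine, or a longer chain on this nitrogen, would compare.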